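This account rests on a few compounds, and the source may have more. Where it says the series, first, only, none or still open, it means among the compounds named here.

Three compounds sharing one core, and differing only in the group on an aromatic nitrogen, have been tested in a functional assay for antagonist activity at corticotropin-releasing factor receptor 1 (Rattus norvegicus); a lower number here means a stronger inhibitor, a higher number a weaker inhibitor. Compound 1 `CC[C@H](C1CC1)n1c(=O)c(C)nc2c(-c3ccc(Cl)cc3Cl)ccnc21` carries a 1-cyclopropylpropyl group there and gives 8.2 nM. Compound 2 `CCCC(C)n1c(=O)c(C)nc2c(-c3ccc(Cl)cc3Cl)ccnc21` carries a 1-methylbutyl group and gives 62 nM. Compound 3 `CC[C@@H](COC)n1c(=O)c(C)nc2c(-c3ccc(Cl)cc3Cl)ccnc21` carries a 1-(methoxymethyl)propyl group and gives 74 nM, the highest number of the three; it sits close to compound 2, with a 1.2-fold higher number from compound 2 to compound 3 (0.08 log units; within the scatter), while the gap from compound 1 is wider, with a 9.0-fold higher number from compound 1 to compound 3 (0.96 log units; beyond the scatter).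

Compound 4 `Cc1nc2c(-c3ccc(Cl)cc3Cl)ccnc2n(C(C)C(C)C)c1=O` has not yet been measured. It differs from compound 3 in one place: 1,2-dimethylpropyl in place of 1-(methoxymethyl)propyl on an aromatic nitrogen. The change swaps one open chain for another that has no oxygen and is branched at two points. The step from compound 2 to compound 3 shows that two such chains, one with and one without the oxygen, can give numbers within the usual scatter of each other. Only compound 1, whose branch is a ring, moves the number by a modest amount. A branched open chain might fall anywhere between these outcomes, so a small to modest move to a lower number is expected for compound 4, with wide uncertainty, as a 2.5-fold lower number from compound 3 to compound 4 (0.39 log units; beyond the scatter). Compound 4 is therefore estimated at 30 nM, with a range from 8 nM to 110 nM.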

Compound 4, half-maximal inhibitory concentration: 380 nM
Compound 4: middle estimate off by 13-fold (1.10 log units), on the low side; the measured number lies above the stated range.
By their numbers in this assay, from the lowest: compound 1; then compounds 2 and 3 (each within the scatter of the next); then compound 4.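

The result shows that this position separates one open chain from another: in this assay, with isopropyl in place of propyl on the chain carbon bound to the aromatic nitrogen, there is a 6.1-fold higher number from compound 2 to compound 4 (0.79 log units; beyond the scatter), and with 1,2-dimethylpropyl in place of 1-(methoxymethyl)propyl there is a 5.1-fold higher number from compound 3 to compound 4 (0.71 log units; beyond the scatter). Compounds 2 and 3 had suggested that open chains might all give similar numbers, but compound 4 goes against that and is the weakest inhibitor of the four, and the ring-bearing group stands furthest from it, with a 46-fold higher number from compound 1 to compound 4 (1.67 log units; beyond the scatter). Nothing measured here explains these gaps.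

Compound 1 and compound 4 differ in both the ring and the length of the chain, so the size of their gap cannot be assigned to either feature alone. A 1-cyclopropylethyl group or a 1-ethylpropyl group would help to pull those two features apart, while a longer chain such as 1-ethylbutyl would show how much further this position tolerates growth.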